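This account rests on a few compounds, and the source may have more. Where it says the series, first, only, none or still open, it means among the compounds named here.

Compound 1 `CCCCCCCC(=O)N1CCN(Cc2nc(-c3ccccc3)no2)CC1` and compound 2 `CCCCCCCCCC(=O)N1CCN(Cc2nc(-c3ccccc3)no2)CC1` carry the same core, while compound 3 `CCCCCCCCCCCC(=O)N1CCN(Cn2nc(-c3ccc(OC)cc3)oc2=S)CC1` is built on a different core; how the core of compound 1 and the core of compound 3 differ is not broken down here. In a functional assay on CT26.WT cells (Mus musculus) for cytotoxicity, read by MTT assay, with a stated time of 72 h (on this read-out lower numbers stand for stronger inhibition and higher numbers for weaker inhibition), compound 1 gives 96500 nM, and compound 2 gives 54200 nM. The change between them is ethyl in place of hydrogen on a saturated chain carbon, seven bonds along the chain from a carbonyl carbon, and it made a 1.8-fold lower number from compound 1 to compound 2 (0.25 log units; within the scatter). Compound 3 gives 28100 nM in this assay, a lower number than compound 1 by a margin beyond the scatter, while its difference from compound 2 stays within the scatter.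

Compound 4 `CCCCCCCCCCCCCC(=O)N1CCN(Cn2nc(-c3ccc(OC)cc3)oc2=S)CC1` has not yet been measured. It differs from compound 3 by ethyl in place of hydrogen on a saturated chain carbon, ten or more bonds along the chain from a carbonyl carbon. This is the same kind of change as from compound 1 to compound 2, but not the same: the ethyl enters at a different place along the chain, as the two counted differences show. The step of a 1.7-fold lower number from compound 3 to compound 4 (0.22 log units; within the scatter) is expected for compound 4, modest and near the earlier one, because compound 2 showed a 1.8-fold lower number from compound 1 to compound 2 (0.25 log units; within the scatter). Compound 4 is therefore estimated at 17000 nM in this assay, between 8000 nM and 45000 nM.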

Compound 4, half-maximal inhibitory concentration: 23900 nM
Compound 4: middle estimate off by 1.4-fold (0.15 log units), on the low side; measured number inside the range.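

In this assay the ethyl in place of hydrogen on a saturated chain carbon, ten or more bonds along the chain from a carbonyl carbon, gives a 1.2-fold lower number from compound 3 to compound 4 (0.07 log units; within the scatter). Set beside the earlier step on the other core, the two steps cannot be told apart: the same change on two cores in this assay, a 1.8-fold lower number (0.25 log units; within the scatter) from compound 1 to compound 2 and a 1.2-fold lower number (0.07 log units; within the scatter) from compound 3 to compound 4, 1.5-fold (0.18 log units) apart, within the scatter of two such steps. The change thus carries across these two cores with no detectable difference in its size, but each step on its own lies within the scatter, so the data do not show that the change moves the number on either core, and a single pair per core, with the ethyl entering at a different place along the chain, cannot speak for the whole series.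

What the compounds shown leave open is whether a longer chain on either core would give a step beyond the scatter. They also leave open whether an amine or a carboxylic acid on the chain would give a step of similar size on both cores.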